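Nitro to carbamoyl on the benzimidazole: outlook for compound 3

This account rests on a few compounds, and the source may have more. Where it says the series, first, only, none or still open, it means among the compounds named here.

Measured compounds:
compound 1, `Cc1nn(-c2ccccc2)c(Oc2ccc(-c3nc4cc([N+](=O)[O-])ccc4[nH]3)cc2)c1/C=N/Nc1ccccc1`, 50 nM in a functional assay on MCF7 cells (Homo sapiens) for cytotoxicity, read by sulforhodamine B assay, with a stated time of 48 h, in the presence of a further agent that is not named here; a higher number here means a weaker inhibitor of growth, a lower number a stronger inhibitor of growth
compound 2, `Cc1nn(-c2ccccc2)c(Oc2ccc(-c3nc4cc([N+](=O)[O-])ccc4[nH]3)cc2)c1/C=N/NC(N)=O`, 50 nM in this assay

Going by the values given here, compound 2 stands level with compound 1 at the digits printed; the step of no change at the digits printed from compound 1 to compound 2 (within the scatter) lies within the scatter, and no further measured compound exists here for comparison.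

Compound 3, `Cc1nn(-c2ccccc2)c(Oc2ccc(-c3nc4cc(C(N)=O)ccc4[nH]3)cc2)c1/C=N/NC(N)=O`, is not yet measured. It differs from compound 2 by carbamoyl in place of nitro on an aromatic carbon. Among the compounds with values here, the only measured step, no change at the digits printed from compound 1 to compound 2 (within the scatter), concerns the group on the amine nitrogen and leaves the benzimidazole part untouched, so no measured step bears on this change, and the numbers give no direction for it. Within the data shown here, the change on the benzimidazole is set against no precedent; the expected step of a 2.0-fold higher number from compound 2 to compound 3 (0.30 log units; within the scatter) is a modest loss, with the range kept wide to reflect the lack of any comparable step. Compound 3 is estimated at 100 nM in this assay, between 30 nM and 400 nM.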

Compound 3, concentration for 50% growth inhibition: > 100000 nM
Compound 3 ended at the assay's limit; the forecaster's own chance of this, stated with the estimate: 5%; middle value at least 1000-fold (3.00 log units) from the limit.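

Carbamoyl in place of nitro on the aromatic carbon gives an at least 2000-fold higher number from compound 2 to compound 3 (3.30 log units; beyond the scatter), so the 5-nitro-1H-benzimidazol-2-yl part of the series does not accept every group of this size. The step on the amine nitrogen, no change at the digits printed from compound 1 to compound 2 (within the scatter), left the reading level, whereas this change is the first shown in the series to carry a large step. The reading for compound 3 is a limit of this assay and not a number, and the full size of the step stays unknown: the limit of > 100000 nM in this assay, at which 1 of the 3 values shown sits.

With only two groups shown at this position, it remains open whether the step follows from losing nitro or from gaining carbamoyl; a nitrile, an amine or a carboxylic acid there would help to separate the two. Also open, as far as these compounds go, is whether the same change behaves alike with phenyl on the amine nitrogen, as in compound 1.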